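This account rests on a few compounds, and the source may have more. Where it says the series, first, only, none or still open, it means among the compounds named here.

Compound 2 `CCOc1ccccc1N1CCN(CCCNc2ncccc2C(=O)N(C)C)CC1` gives 7.94 nM in a functional assay on aorta for antagonist activity at Alpha-1D adrenergic receptor (Rattus norvegicus) (on this read-out higher numbers stand for weaker binding and lower numbers for tighter binding), and compound 1 `CN(C)C(=O)c1cccnc1NCCCN1CCN(c2ccccc2)CC1` gives 15.9 nM. Compound 2 holds the lower of the two numbers, but the step of a 2.0-fold lower number from compound 1 to compound 2 (0.30 log units; within the scatter) stays within the scatter. Compound 3 `CN(C)C(=O)c1cccnc1NCCCN1CCN(c2ccccc2OC(F)(F)F)CC1` differs from compound 2 by trifluoromethyl in place of ethyl on an oxygen on an aromatic ring. Going by the values given here, no measured step touches this change; the only step known concerns the ethoxy itself and was within the scatter, so for compound 3 no movement beyond the scatter is expected in this assay. For compound 3 the expected step is a 1.0-fold higher number from compound 2 to compound 3 (0.00 log units; within the scatter). Compound 3 is estimated at 8 nM in this assay, within 3 nM to 25 nM.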

Compound 3, dissociation constant: 100 nM
Compound 3: the middle estimate sits 13-fold (1.10 log units) below what was measured, outside the stated range (above it).
By their numbers in this assay, from the lowest: compounds 2 and 1 (each within the scatter of the next); then compound 3.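

In this assay the group on an oxygen on an aromatic ring clearly matters: trifluoromethyl in place of ethyl gives a 13-fold higher number from compound 2 to compound 3 (1.10 log units; beyond the scatter) while the earlier ethoxy step stayed within the scatter. Trifluoromethoxy in place of hydrogen likewise gives a 6.3-fold higher number from compound 1 to compound 3 (0.80 log units; beyond the scatter) and so, unlike ethoxy, moves the number beyond the scatter. No evidence on hand explains these steps.

Still open, going by these compounds, is whether methoxy or a longer chain such as propoxy stays with ethoxy or moves as trifluoromethoxy does. Also open, on these data alone, is how chlorine or methyl on that aromatic carbon would read.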